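A few compounds are considered here, and "the series" means these few. Any claim that something is new, unique, unknown or untested is made for them only; others in the source may bear on it.

Compound 1 `Cc1cccc(Cc2cnc(CCc3ccc(-c4ccccc4C(=O)O)cc3)[nH]2)c1` gives 4310 nM in an in vitro functional assay on cells for agonist activity at Bombesin receptor subtype-3 (Homo sapiens), read by luminescence and calcium flux (a lower number here means that less compound is needed, a higher number that more compound is needed for the effect), the lower of the two numbers recorded there. Compound 2 `CCCCc1cnc(CCCc2ccc(-c3ccccc3C(=O)O)cc2)[nH]1` gives 5600 nM in this assay, a gap from compound 1 that lies within the scatter of repeated measurements, so the two are not separated. Compound 3 `CCCCc1cnc(Cc2ccc(-c3ccccc3C(=O)O)cc2)[nH]1` reaches in this assay only a limit, > 10000 nM, and no number; one of the three values sits at that limit (the limit of > 10000 nM in this assay, at which 1 of the 3 values shown sits).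

Compound 4 `O=C(O)c1ccccc1-c1ccc(CCc2ncc(Cc3ccccc3Cl)[nH]2)cc1` is the untested partner of compound 1. The change is 2-chlorophenyl in place of 3-methylphenyl on a saturated chain carbon bound to an aromatic carbon. For the measured compounds named here, no measured pair isolates this change, so its effect is unknown from the data; the expected step is small, within the scatter, in either direction a 1.0-fold higher number from compound 1 to compound 4 (0.02 log units; within the scatter). Compound 4 is therefore estimated at 4500 nM, ranging from 1500 nM to 13000 nM.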

Compound 4, half-maximal effective concentration: 292 nM
Compound 4: the middle estimate sits 15-fold (1.19 log units) above what was measured, outside the stated range (below it).
By their numbers in this assay, from the lowest: compound 4; then compounds 1 and 2 (each within the scatter of the next). At a limit, above all of these: compound 3.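

For the compounds shown here, compound 1 and compound 4 are the first pair here that differ in one place, and with 2-chlorophenyl in place of 3-methylphenyl, a 15-fold lower number from compound 1 to compound 4 (1.17 log units; beyond the scatter) in this assay marks this position on a saturated chain carbon bound to an aromatic carbon as sensitive to the group it carries. The two groups have the same count of heavy atoms, yet the step lies well beyond the scatter. Nothing measured here accounts for this step.

The change replaces the methyl with chlorine and moves the substituent together, so the contribution of each stays unresolved. From the compounds shown here alone, it also remains open how a bromine or a methoxy group would fare on this ring.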